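The source may report more compounds than this note shows. Statements on the series, on what has been measured and on what is new or still open speak of the compounds shown alone.

Measured compounds:
Compound 1, `CC(=O)OC(C)n1cnc2c(Cl)nc(N)nc21`; in a functional assay on MOLT-4 cells (Homo sapiens) for inhibition (on this read-out lower numbers stand for stronger inhibition and higher numbers for weaker inhibition), compound 1 gives > 500000 nM, which is a limit of the assay rather than a number.
Compound 2, `CC(=O)OC(C)n1cnc2c(Cl)nc(I)nc21`; in this assay compound 2 gives 12300 nM.

Within the data shown here, compound 2 therefore stands as the only compound of the pair with a measured number; the other value is a limit, as noted in the limit of > 500000 nM in this assay, at which 1 of the 2 values shown sits. Among the measured compounds shown here, the single measured step, an at least 40-fold lower number from compound 1 to compound 2 (1.60 log units; beyond the scatter), shows that exchanging the amino group for iodo moves the read-out strongly.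

Compound 3, `CC(=O)OC(C)n1cnc2c(Cl)nc(F)nc21`, is not yet measured. It differs from compound 2 by fluoro in place of iodo on an aromatic carbon. For the measured compounds named here, the one step in hand concerns the same position but a different exchange, so it bears on compound 3 only loosely: it shows that this position responds to substitution, but gives no direct reading for fluoro against iodo. A step of moderate size in the weaker direction, a 2.8-fold higher number from compound 2 to compound 3 (0.45 log units; beyond the scatter), is expected for compound 3, with wide uncertainty. Compound 3 is thus estimated at 35000 nM in this assay, between 8000 nM and 200000 nM.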

Compound 3, half-maximal inhibitory concentration: 41000 nM
The estimate for compound 3 lay 1.2-fold (0.07 log units) below the measured number; the range from low to high includes it.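

Working notes: in this assay, the choice of halogen at this position matters, as fluoro in place of iodo gives a 3.3-fold higher number from compound 2 to compound 3 (0.52 log units; beyond the scatter), so iodo holds the lower number of the two. Fluoro in place of amino gives an at least 12-fold lower number from compound 1 to compound 3 (1.08 log units; beyond the scatter), so the large drop first seen with iodo is not confined to that one halogen, and the step between the two halogens is the smaller change at this carbon. The steps from compound 1 give only a minimum size, as compound 1 stands at a limit of the assay rather than at a number: the limit of > 500000 nM in this assay, at which 1 of the 3 values shown sits.

With only iodo and fluoro among the halogens here, the compounds shown leave open whether bromo or chloro at this position would fall between them or outside them, and how a non-halogen group such as methoxy, methyl or nitrile would compare. From the compounds shown here alone, the chloro group and the ester-bearing chain stay the same across all three compounds, so the effect of an amine in place of that chloro group, or of a longer chain in place of that ester-bearing chain, also remains open.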